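The compounds below may be only part of what the source reports. "The series", "measured", "known", "first", "only" and "open" are said of these compounds alone.

Measured compounds:
compound 1, `O=C(O)C1CCN(c2ccccc2)C1`, 48000 nM in an assay on cells for inhibition of Palmitoleoyl-protein carboxylesterase NOTUM variant C330S (Homo sapiens), read by fluorescence, with a stated time of 40 min; on this read-out lower numbers stand for stronger inhibition and higher numbers for weaker inhibition
compound 2, `Cc1c(C(=O)O)ccn1-c1ccccc1`, 3800 nM in this assay
compound 3, `Cc1c(C(=O)O)cc(C(F)(F)F)n1-c1ccccc1`, 22000 nM in this assay

Compound 2 and compound 3 share a core, and compound 3 carries the change (trifluoromethyl in place of hydrogen on an aromatic carbon). Going by the values given here, that step, a 5.8-fold higher number from compound 2 to compound 3 (0.76 log units; beyond the scatter), is the only measured precedent in the set. Compound 1 rests on a different core; how the two cores differ is not broken down here. Compound 1 gives the highest number of the three, with compound 3 nearest and compound 2 furthest from it.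

Compound 4, `O=C(O)C1CCN(c2ccc(C(F)(F)F)cc2)C1`, has not yet been measured in this assay. It differs from compound 1 by trifluoromethyl in place of hydrogen on an aromatic carbon. This is the same kind of change as from compound 2 to compound 3, but not the same: there the group enters a five-membered aromatic ring with one nitrogen, next to the ring nitrogen and next to the ring atom that bears a phenyl group; here it enters a six-membered aromatic ring of carbon only, para to a group of 8 heavy atoms. Because a 5.8-fold higher number from compound 2 to compound 3 (0.76 log units; beyond the scatter) went toward a weaker result, a step of a 1.9-fold higher number from compound 1 to compound 4 (0.27 log units; within the scatter) is expected from compound 1 to compound 4. Compound 4 is therefore estimated at 90000 nM in this assay, with a range from 25000 nM to 300000 nM expected.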

Compound 4, half-maximal inhibitory concentration: 50000 nM
Compound 4: middle estimate off by 1.8-fold (0.26 log units), on the high side; the measured number falls inside the stated range.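

Trifluoromethyl in place of hydrogen on an aromatic carbon gives a 1.0-fold higher number from compound 1 to compound 4 (0.02 log units; within the scatter) in this assay, so the weakening seen with this change on the other core is not repeated on the core of compound 1. The two steps for this one change do not agree: the same change on two cores in this assay, a 5.8-fold higher number (0.76 log units; beyond the scatter) from compound 2 to compound 3 and a 1.0-fold higher number (0.02 log units; within the scatter) from compound 1 to compound 4, 5.6-fold (0.74 log units) apart, beyond the scatter of two such steps. This shows that the step measured on one core could not be carried over unchanged to the other in this series, but with a single pair on each core, and with the group entering a different kind of ring on each, it does not show what sets the gap or whether the core or the place of substitution matters more.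

The compounds shown leave open whether a chlorine atom, a methoxy group or a nitrile on the same aromatic carbon would also leave the number of compound 1 within the scatter. They also leave open how either core would respond if a primary amide replaced the carboxylic acid.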